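A few compounds are considered here, and "the series" means these few. Any claim that something is new, unique, unknown or untested is made for them only; others in the source may bear on it.

Measured so far:
compound 1, `CN(C)Cc1ccc2oc(-c3ccccc3Cl)cc(=O)c2c1`: 54.3%
compound 2, `COc1ccc(-c2cc(=O)c3cc(CCl)ccc3o2)cc1`: 38.7%

Both were run in a functional assay on the whole organism (strain Wistar albino) for inhibition, with Rattus norvegicus as the target, read by paw edema, with stated times of 30 min and 3 h, at a dose of 20 mg/kg by the oral route; a higher number here means more inhibition at the dose given (going by the name of the read-out), a lower number less inhibition. Compound 2 stands lowest of the two numbers; compound 1 gives 54.3%, a gap beyond the scatter. For the measured compounds named here, the two differ in more than one place, so no single step is drawn between them.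

Compound 3, `COc1ccc(-c2cc(=O)c3cc(CN(C)C)ccc3o2)cc1`, is not yet measured. It comes from compound 2 by dimethylamino in place of chloro on a saturated chain carbon bound to an aromatic carbon. For this change a modest rise in this assay is expected, though the two measured compounds cannot fix its size. Compound 3 is expected to give 48%, in the range 36% to 60%, an expected step of a number 9.3 percentage points higher from compound 2 to compound 3 (within the scatter).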

Compound 3, a percentage reported as inhibition, in the whole organism at one dose (the size of the read-out at that dose, not a potency): 53.1%
Estimate against measurement, compound 3: 5.1 percentage points below, and the stated range covers the measured number.
By their numbers in this assay, from the lowest: compound 2; then compounds 3 and 1 (each within the scatter of the next).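

In this assay, for the compounds shown here, dimethylamino in place of chloro on a saturated chain carbon bound to an aromatic carbon gives a number 14.4 percentage points higher from compound 2 to compound 3 (beyond the scatter), the first single-place comparison. With (dimethylamino)methyl in both, compound 3 at 53.1% and compound 1 at 54.3% lie within the scatter of each other. No measurement on hand accounts for the step.

Open, going by these compounds, is whether a cyclic amine such as morpholine or piperidine, or a longer chain carrying the dimethylamino, would hold this level of inhibition.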